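Trading 3-methylphenyl for 4-methylphenyl on a shared core

This account rests on a few compounds, and the source may have more. Where it says the series, first, only, none or still open, it means among the compounds named here.

Of the compounds shown here, three built on one shared core have been tested in a functional assay on MCF7 cells (Homo sapiens) for antiproliferative activity, read by MTT assay, with a stated time of 72 h; a higher number here means a weaker inhibitor, a lower number a stronger inhibitor. Compound 1 `O=S(=O)(Oc1ccccc1Cl)C1CC2OC1C(c1ccc(/C=C/c3cc(O)cc(O)c3)cc1)=C2c1ccc(O)cc1` gives 40400 nM and compound 2 `Cc1ccccc1OS(=O)(=O)C1CC2OC1C(c1ccc(/C=C/c3cc(O)cc(O)c3)cc1)=C2c1ccc(O)cc1` gives 55800 nM, which is a 1.4-fold higher number from compound 1 to compound 2 (0.14 log units; within the scatter). Compound 3 `Cc1cccc(OS(=O)(=O)C2CC3OC2C(c2ccc(/C=C/c4cc(O)cc(O)c4)cc2)=C3c2ccc(O)cc2)c1` gives 16300 nM, the lowest number of the three and the most potent result so far.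

The next compound to be tested is compound 4 `Cc1ccc(OS(=O)(=O)C2CC3OC2C(c2ccc(/C=C/c4cc(O)cc(O)c4)cc2)=C3c2ccc(O)cc2)cc1`. It has 4-methylphenyl in place of the 3-methylphenyl of compound 3, on an oxygen whose other neighbour is sulfonyl sulfur (4-methylphenyl in place of 3-methylphenyl on an oxygen). Going by the values given here, no tested compound carries 4-methylphenyl, so the guide must come from the other changes at this oxygen. The closest is the swap between two methylphenyl groups, a 3.4-fold lower number from compound 2 to compound 3 (0.53 log units; beyond the scatter). The swap from 2-chlorophenyl gave a 2.5-fold lower number from compound 1 to compound 3 (0.39 log units; beyond the scatter). Changes at this oxygen have therefore shifted the number modestly, not dramatically. With compound 3 at 16300 nM as the lowest of the three, a small move upward seems likelier than a further drop, though the data cannot rule out a drop. The expected result is a 1.5-fold higher number from compound 3 to compound 4 (0.19 log units; within the scatter). Compound 4 is estimated at 25000 nM, with an expected range from 10000 nM to 60000 nM.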

Compound 4, half-maximal inhibitory concentration: 9200 nM
Estimate against measurement, compound 4: 2.7-fold (0.43 log units) above, outside the stated range (below it).
By their numbers in this assay, from the lowest: compounds 4 and 3 (each within the scatter of the next); then compounds 1 and 2 (each within the scatter of the next).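

In this assay, replacing 3-methylphenyl with 4-methylphenyl on the oxygen bonded to the sulfonyl sulfur gives a 1.8-fold lower number from compound 3 to compound 4 (0.25 log units; within the scatter) and so sets no order between these two compounds. Going by these compounds alone, the 2-methylphenyl group now stands apart from both other methylphenyl groups, since the change to 4-methylphenyl gives a 6.1-fold lower number from compound 2 to compound 4 (0.78 log units; beyond the scatter) and adds a second separation to the one already seen with compound 3. The 2-chlorophenyl group behaves in the same way, with a 4.4-fold lower number from compound 1 to compound 4 (0.64 log units; beyond the scatter) and thus a split of the four compounds into two groups, compound 3 with compound 4 and compound 1 with compound 2, that none of the four goes against.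

The compounds shown leave open whether 3-chlorophenyl or 4-chlorophenyl would sit with compound 3 and compound 4, and whether a longer chain such as 4-ethylphenyl, or an amine or a carboxylic acid on the ring, would keep that place in the split. Nothing available here bears on what lies behind the split itself.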